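Swapping the Indanol for a Carbamate on the Amine

The compounds below may be only part of what the source reports. "The series", "measured", "known", "first", "only" and "open" are said of these compounds alone.

Measured so far:
compound 1, `c1ccc(C2CCCCN2C2CCN(CCCc3c[nH]c4ccc(-n5cnnc5)cc34)CC2)cc1`: 65%
compound 2, `O[C@@H]1Cc2ccccc2[C@H]1NC1CCN(CCCc2c[nH]c3ccc(-n4cnnc4)cc23)CC1`: 75%
compound 3, `CC(=O)Nc1ccc([C@H](C)NCC2CCN(CCCc3c[nH]c4ccc(-n5cnnc5)cc34)CC2)cc1`: 99%

All three share the same core and differ only in the group carried on the amine nitrogen. In a functional assay on CHO cells for activation of 5-hydroxytryptamine receptor 1D (Homo sapiens), read by GTPgammaS binding (a lower number here means a smaller maximal response, a higher number a larger maximal response), compound 2 stands second highest of the three. Its nearest neighbour is compound 1, whose value lies within the scatter of compound 2, so the two cannot be told apart. Compound 3 is the furthest away, with a value that lies beyond the scatter above compound 2.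

Compound 4, `NC(=O)OC[C@H](NC1CCN(CCCc2c[nH]c3ccc(-n4cnnc4)cc23)CC1)c1ccccc1`, is the next variation on this amine. Compared with compound 2 the change is 2-(carbamoyloxy)-1-phenylethyl in place of 2-hydroxy-2,3-dihydro-1H-inden-1-yl on an amine nitrogen.

For the measured compounds named here, no pair among the measured compounds differs in just one place, so there is no measured step to lean on. What the three values do show is that the amine substituent can move the largest response over a fair span, and that the open-chain substituent of compound 3 gave the highest number. On that basis the step from compound 2 to compound 4 is expected to be a modest rise, near the edge of the scatter, of a number 10 percentage points higher from compound 2 to compound 4 (within the scatter). Compound 4 is therefore estimated at 85%, within the range 68% to 100%.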

Compound 4, largest response reached (reported as efficacy), in percent of the reference or control that the assay uses: 73%
Compound 4: the middle estimate sits 12 percentage points above what was measured; measured number inside the range.
By their numbers in this assay, from the lowest: compounds 1, 4 and 2 (each within the scatter of the next); then compound 3.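

In this assay, for the compounds shown here, putting 2-(carbamoyloxy)-1-phenylethyl in place of 2-hydroxy-2,3-dihydro-1H-inden-1-yl on this amine nitrogen gives a number 2 percentage points lower from compound 2 to compound 4 (within the scatter), the first step in this set between compounds that differ in one place, and it leaves the two compounds indistinguishable. For this one pair, then, the largest response stays within the scatter even though the five-membered non-aromatic ring leaves, the defined stereocentres drop from 2 to 1, and a group with 2 hydrogen-bond acceptors enters in place of one with 1. Nothing available on this pair offers an explanation for that outcome.

Open, as far as these compounds go, is what the carbamoyloxy part contributes by itself: a plain hydroxyl or an amine in its place on the same 1-phenylethyl chain would separate its share from that of opening the five-membered ring. Also open, from the compounds shown here alone, is whether the defined stereocentre of compound 4 matters, which the mirror-image arrangement at that carbon, with the same 2-(carbamoyloxy)-1-phenylethyl group on the amine nitrogen, would answer.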